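The source may report more compounds than this note shows. Statements on the series, on what has been measured and on what is new or still open speak of the compounds shown alone.

Compound 3 `CCCCCCCCN(C)S(=O)(=O)NC(=O)Oc1c(C(C)(C)C)cc(C)cc1C(C)(C)C` belongs to a set of three carbamates in which a sulfamoyl group is attached to the carbamate nitrogen. In an assay on liver for inhibition of sterol O-acyltransferase 1 (Rattus norvegicus), using microsomes (on this read-out lower numbers stand for stronger inhibition and higher numbers for weaker inhibition), compound 3 gives 18000 nM, the second highest of the three numbers. Its nearest neighbour is compound 1 `CC(C)(C)c1cccc(C(C)(C)C)c1OC(=O)NS(=O)(=O)Nc1ccccc1`, which in this assay gives 19000 nM, a difference that lies within the usual scatter, so the two cannot be ordered. Within the data shown here, the furthest is compound 2 `CCCCN(CCCC)S(=O)(=O)NC(=O)Oc1c(C(C)(C)C)cc(C)cc1C(C)(C)C`, which in this assay gives 3200 nM; the only step measured, a 5.6-fold higher number from compound 2 to compound 3 (0.75 log units; beyond the scatter), separates it from compound 3.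

Compound 4 `Cc1cc(C(C)(C)C)c(OC(=O)NS(=O)(=O)Nc2ccccc2)c(C(C)(C)C)c1` is the next compound to be examined. It differs from compound 3 in one place: anilino in place of methyl(octyl)amino on a sulfonyl sulfur. Among the measured compounds shown here, no measured step covers this exchange directly. The step from compound 2 to compound 3 shows that the group on the sulfonyl sulfur can move the number by a modest amount, and compound 1, which carries the same anilino group as compound 4 on a core lacking the ring methyl, sits close to compound 3. The step in this assay is therefore expected to be small, a 1.1-fold lower number from compound 3 to compound 4 (0.02 log units; within the scatter), with no clear direction beyond the scatter. For compound 4 the estimate in this assay is 17000 nM, within a range from 5000 nM to 55000 nM.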

Compound 4, half-maximal inhibitory concentration: 23400 nM
For compound 4 the middle estimate is 1.4-fold (0.14 log units) below the measured one; measured number inside the range.
By their numbers in this assay, from the lowest: compound 2; then compounds 3, 1 and 4 (each within the scatter of the next).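

In this assay, anilino in place of methyl(octyl)amino on the sulfonyl sulfur gives a 1.3-fold higher number from compound 3 to compound 4 (0.11 log units; within the scatter) and so does not separate the aromatic group from the long chain, while anilino in place of dibutylamino gives a 7.3-fold higher number from compound 2 to compound 4 (0.86 log units; beyond the scatter) and sets compound 2 apart from compound 4. Among these compounds, on this shared core, dibutylamino is therefore the only one of the three groups whose number differs from the others beyond the scatter. The result also gives the first reading on the aromatic carbon, where methyl in place of hydrogen, with anilino kept on the sulfonyl sulfur, gives a 1.2-fold higher number from compound 1 to compound 4 (0.09 log units; within the scatter) and so makes no difference that can be told from the scatter; no evidence shown here accounts for any of these numbers.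

The compounds shown leave open whether the lower number of compound 2 needs both butyl chains or would also appear with diethylamino or piperidine on the sulfonyl sulfur. They also leave open whether the ring methyl would matter with dibutylamino in place of anilino, and whether a chloro or methoxy group on the anilino ring would move the number.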